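From 2-chlorophenyl to 3-methylphenyl on a shared core

This account rests on a few compounds, and the source may have more. Where it says the series, first, only, none or still open, it means among the compounds named here.

Measured in a functional assay on HL-60 cells (Homo sapiens) for cytotoxicity, read by WST assay, with a stated time of 48 h; on this read-out lower numbers stand for an effect already at smaller amounts and higher numbers for an effect only at larger amounts of compound:
- Compound 1 `CCCCCCCOc1ccccc1C[C@H]1C(=O)OC[C@@H]1Cc1ccccc1`: 75000 nM
- Compound 2 `O=C1OC[C@H](Cc2ccccc2)[C@H]1Cc1ccccc1C(F)(F)F`: 37000 nM
- Compound 3 `O=C1OC[C@H](Cc2ccccc2)[C@H]1Cc1ccccc1Cl`: 37000 nM

Compound 3 stands level with compound 2, and together they hold the lowest of the three numbers. Compound 4 `Cc1cccc(C[C@H]2C(=O)OC[C@@H]2Cc2ccccc2)c1` has not yet been measured. It carries 3-methylphenyl in place of 2-chlorophenyl on a saturated chain carbon bound to a saturated ring carbon.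

Among the compounds with values here, three measured steps bear on this change, all on the same aromatic ring. Chloro in place of trifluoromethyl gave no change at the digits printed from compound 2 to compound 3 (within the scatter). Trifluoromethyl in place of heptyloxy gave a 2.0-fold lower number from compound 1 to compound 2 (0.31 log units; beyond the scatter), and chloro in place of heptyloxy gave a 2.0-fold lower number from compound 1 to compound 3 (0.31 log units; beyond the scatter). Within the data shown here, these steps are modest or absent, but no measured compound carries 3-methylphenyl, so they offer only a loose guide. In this assay, no step beyond the scatter is therefore expected, with a slight upward drift at most. The estimate amounts to a 1.2-fold higher number from compound 3 to compound 4 (0.09 log units; within the scatter), an expected step. For compound 4 the estimated value is 45000 nM, with an expected range of 22000 nM to 90000 nM.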

Compound 4, half-maximal effective concentration: 53000 nM
Compound 4: middle estimate off by 1.2-fold (0.07 log units), on the low side, within the range that was stated.
By their numbers in this assay, from the lowest: compounds 2, 3, 4 and 1 (each within the scatter of the next, the first and the last beyond it).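

In this assay, 3-methylphenyl in place of 2-chlorophenyl on a saturated chain carbon bound to a saturated ring carbon gives a 1.4-fold higher number from compound 3 to compound 4 (0.16 log units; within the scatter). This is the first change shown in which the substituted ring loses its chlorine and becomes a ring of carbon only with a methyl group, and the number stays within the scatter. Because the names 2-chlorophenyl and 3-methylphenyl differ in both the group and its numbered place, this single step cannot separate the two, and no measurement at hand offers an explanation for the result.

The compounds shown leave open how much of the step belongs to the group and how much to its place. They also leave open whether an amine or a carboxylic acid on this aromatic ring would give a step beyond the scatter.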